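Swapping a thiophene for a methoxyphenyl: expected cytotoxicity

The source may hold more compounds than are shown below. What is called first, only, known or untested is meant among the compounds shown, and "the series" means these compounds.

Compound 1 `COC(=O)c1cc(-c2cccc(NC(=O)c3ccc(C4OC4C(=O)c4ccc(Cl)cc4)cc3)c2)on1` was tested in an ADME assay on Vero cells (Chlorocebus sabaeus) for cytotoxicity, read by MTT assay, with a stated time of 72 h; a higher number here means that more compound is tolerated, a lower number that less compound is tolerated. For compound 1 the result is a limit of the assay, > 20 ug/mL, rather than a number. Compound 2 `COC(=O)c1cc(-c2cccc(NC(=O)c3ccc(/C=C/C(=O)c4cccs4)cc3)c2)on1` shares the same core but carries a different end group; in this assay compound 2 gives "not determined" (no result reported), so no figure stands beside it. Compound 3 `COC(=O)c1cc(-c2cccc(NC(=O)c3ccc(/C=C/C(=O)c4ccccc4OC)cc3)c2)on1` differs from compound 2 in one place: 2-methoxyphenyl in place of thiophen-2-yl on a carbonyl carbon. For the measured compounds named here, no measured step connects two compounds here, so the size of any change for compound 3 cannot be read from a neighbouring pair, and the most likely outcome is again a limit rather than a shift beyond the scatter. Compound 3 is expected to give about 25 ug/mL in this assay, within a range from 10 ug/mL to 60 ug/mL. That expectation rests on compound 1, which sits at the limit of > 20 ug/mL in this assay, at which 1 of the 2 values shown sits.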

Compound 3, half-maximal cytotoxic concentration: > 40 ug/mL
Compound 3: only a limit was reported; the forecaster's own chance of this, stated with the estimate: 70%; middle value at least 1.6-fold (0.20 log units) from the limit.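

For the compounds shown here, compound 1 and compound 3 each stand at a limit of the assay rather than a number, and compound 2 gives no figure, so no step among them can be read. Left open is whether 2-methoxyphenyl or thiophen-2-yl is better tolerated in this assay.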